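The source may report more compounds than this note shows. Statements on the series, on what has been measured and on what is new or still open speak of the compounds shown alone.

Among the measured compounds shown here, compound 1 `O=c1c2ccccc2c(-c2cccnc2)nn1Cc1cccc(Cl)c1` is one of three compounds measured in an assay on isolated protein (Oryctolagus cuniculus) with Thromboxane-A synthase (Homo sapiens) as the target, tested at 1 uM (on this read-out higher numbers stand for more inhibition at the one concentration tested (going by the name of the read-out) and lower numbers for less inhibition), and compound 1 gives 95% there. Compound 2 `COC(=O)c1ccc(Cn2nc(-c3cccnc3)c3ccccc3c2=O)cc1` gives 95% in this assay, level with compound 1 at the digits reported, and compound 3 `O=c1c2ccccc2c(-c2cccnc2)nn1CCNS(=O)(=O)c1ccccc1` gives 93%, a reading within the scatter of both. Compound 4 `CC(C)NC(=O)CCCn1nc(-c2cccnc2)c2ccccc2c1=O` has not been measured. It differs from compound 1 in one place: 2-(isopropylcarbamoyl)ethyl in place of 3-chlorophenyl on a saturated chain carbon bound to an aromatic nitrogen. For the measured compounds named here, no step between two measured compounds is available to calibrate such a swap, but the measured compounds carry quite different groups on the same chain carbon and all read high, so only a small downward step, within or barely beyond the scatter, is expected, a number 8 percentage points lower from compound 1 to compound 4 (within the scatter). Compound 4 is accordingly expected to give about 87% in this assay, between 70% and 97%.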

Compound 4, a percentage reported as inhibition, at one concentration (the size of the read-out at that concentration, not a potency): 89%
For compound 4 the middle estimate is 2 percentage points below the measured one, within the range that was stated.
By their numbers in this assay, from the lowest: compounds 4, 3, 1 and 2 (each within the scatter of the next).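

In this assay, 2-(isopropylcarbamoyl)ethyl in place of 3-chlorophenyl gives a number 6 percentage points lower from compound 1 to compound 4 (within the scatter) on a saturated chain carbon bound to an aromatic nitrogen. The reading at this position therefore stays high without any ring in the group, and with a hydrogen-bond donor and acceptor present. No measurement given bears on the reason for this result.

With all four readings this high at one concentration, any differences in potency among these groups remain open. So does the reading for a carboxylic acid, an amine or a longer chain on that carbon.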